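A few compounds are considered here, and "the series" means these few. Any claim that something is new, unique, unknown or untested is made for them only; others in the source may bear on it.

Working notes on the series. The shared core is held constant; the variable part is the substituent on the saturated ring carbon of the piperidine. Compound 1 `COc1cc(COc2cc(N)c(Cl)cc2C(=O)CCCCN2CCC(c3ccccc3)CC2)cc(OC)c1` carries a phenyl there and in a functional assay for antagonist activity at 5-hydroxytryptamine receptor 4 (Rattus norvegicus) (a lower number here means a less potent compound, a higher number a more potent compound, by a factor of ten per unit of this negative logarithm), compound 1 gives 7.7. Compound 2 `COc1cc(COc2cc(N)c(Cl)cc2C(=O)CCCCN2CCC(NS(C)(=O)=O)CC2)cc(OC)c1` carries a methanesulfonamido at the same place, and in this assay compound 2 gives 8.4. For the measured compounds named here, the one step measured so far, a number 0.70 log units higher from compound 1 to compound 2 (beyond the scatter), puts compound 2 at the top of the two numbers, with compound 1 as the only other point.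

Compound 3 `COc1cc(COc2cc(N)c(Cl)cc2C(=O)CCCCN2CCC(CNS(C)(=O)=O)CC2)cc(OC)c1` is the next member. The change from compound 2 is (methanesulfonamido)methyl in place of methanesulfonamido on a saturated ring carbon. Going by the values given here, no measured step shows the effect of inserting one carbon between this ring position and the sulfonamide; the step from compound 1 to compound 2 concerns a different exchange at the same position and is only a loose guide. The expectation for this assay is therefore a small step, a number 0.20 log units lower from compound 2 to compound 3 (within the scatter), not clearly beyond the scatter in either direction. For compound 3 the estimate in this assay is 8.2, expected between 7.6 and 8.8.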

Compound 3, negative logarithm of the antagonist equilibrium constant: 8.9
Compound 3: the middle estimate sits 0.70 log units below what was measured; the whole stated range lies below it.
By their numbers in this assay, from the lowest: compound 1; then compound 2; then compound 3.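

In this assay, the position three ring bonds from the ring nitrogen responds to the placement of the sulfonamide as well as to the kind of group it carries. Replacing methanesulfonamido with (methanesulfonamido)methyl gives a number 0.50 log units higher from compound 2 to compound 3 (beyond the scatter), even though the hydrogen-bond donor and acceptor counts of the two groups are the same. Measured against phenyl, the same substituent gives a larger step, a number 1.20 log units higher from compound 1 to compound 3 (beyond the scatter), and both sulfonamide-bearing compounds stand above compound 1, with no listed compound going against that order. No measurement at hand bears on why the added carbon raises the number.

The compounds shown leave open whether the number keeps rising with a longer chain, such as a (methanesulfonamido)ethyl group, or whether (methanesulfonamido)methyl is already the best length. They also leave open whether the sulfonamide itself matters at this position, a question that an aminomethyl group, a carboxylic acid or an acetamidomethyl group on the same ring carbon would address.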